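The source may report more compounds than this note shows. Statements on the series, on what has been measured and on what is new or still open speak of the compounds shown alone.

Three compounds that share a carbonyl and a nitrile in their middle part have been tested in a functional assay for inhibition, with a stated time of 30 min, tested at 1 mM; on this read-out lower numbers stand for less inhibition and higher numbers for more inhibition at the one concentration tested (going by the name of the read-out). Compound 1 `COc1cc(/C(Cl)=C/C=C(\C#N)C(=O)c2c[nH]c3ccccc23)cc(OC)c1OC` gives 21.1% in this assay. Compound 3 `COc1cc(/C(Cl)=C/C=C(\C#N)C(=O)c2c(C)[nH]c3ccccc23)cc(OC)c1OC` differs from compound 1 only by methyl in place of hydrogen on an aromatic carbon, a change that, cut one bond further out, reads as 1H-indol-3-yl to 2-methyl-1H-indol-3-yl; in this assay compound 3 gives 14.5%, so that the step of a number 6.6 percentage points lower from compound 1 to compound 3 (within the scatter). Compound 2 `N#C/C(=C\C=C(/Cl)c1ccc(Br)cc1)C(=O)c1c[nH]c2ccccc12` is built on a different core, and the difference between its core and that of compound 1 is not broken down here. In this assay compound 2 gives 18.4%, a number that sits close to those of compound 1 and compound 3, with all three within the usual scatter of one another.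

Compound 4 `Cc1[nH]c2ccccc2c1C(=O)/C(C#N)=C/C=C(\Cl)c1ccc(Br)cc1` has not yet been measured. Going by the values given here, it differs from compound 2 by methyl in place of hydrogen on an aromatic carbon, which is the same change, at the same place, as the one from compound 1 to compound 3. Among the compounds with values here, the one measured example of this change moved the number only within the scatter, so a step of similar size is expected here. The expected step is a number 5.4 percentage points lower from compound 2 to compound 4 (within the scatter), resting on the measured step of a number 6.6 percentage points lower from compound 1 to compound 3 (within the scatter). Compound 4 is therefore estimated to give 13% in this assay, with a range from 3% to 23%.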

Compound 4, a percentage reported as inhibition, at one concentration (the size of the read-out at that concentration, not a potency): 15.8%
For compound 4 the middle estimate is 2.8 percentage points below the measured one, and the stated range covers the measured number.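

The new step in this assay is a number 2.6 percentage points lower from compound 2 to compound 4 (within the scatter), for methyl in place of hydrogen on the aromatic carbon next to the ring nitrogen. Set beside the earlier step, the two results show no difference between the cores that can be told apart from ordinary measurement noise: the same change on two cores in this assay, a number 6.6 percentage points lower (within the scatter) from compound 1 to compound 3 and a number 2.6 percentage points lower (within the scatter) from compound 2 to compound 4, 4 percentage points apart, within the scatter of two such steps. This shows that on both cores the change leaves the number within the usual scatter, so a modest step is a fair expectation for this pair of cores; it does not show that the methyl has a real effect of a fixed size, or that the same would hold on a third core, as two small steps at a single concentration cannot settle either point.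

The compounds shown carry only hydrogen or methyl at this place, so it stays open whether an ethyl group, a longer chain, an amine or a carboxylic acid there would move the number beyond the scatter. Also open, on these data alone, is how these compounds compare in potency, as the read-out gives only the size of the inhibition at one concentration.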